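A few compounds are considered here, and "the series" means these few. Any claim that something is new, unique, unknown or untested is made for them only; others in the source may bear on it.

Three compounds share one core and differ only in the aryl group on a nitrogen on an aromatic ring. In a functional assay on U-87MG ATCC cells for antiproliferative activity against U-87 MG (Homo sapiens), read by spectrophotometry, with a stated time of 2 days (on this read-out lower numbers stand for stronger inhibition of growth and higher numbers for weaker inhibition of growth), compound 1 `Cc1cc(Cl)ccc1Nc1ncc(C(F)(F)F)c(N2Cc3cccc(N(C)S(C)(=O)=O)c3C2)n1` gives 28300 nM. Compound 2 `CN(c1cccc2c1CN(c1nc(Nc3ccc(C(F)(F)F)cc3)ncc1C(F)(F)F)C2)S(C)(=O)=O` reaches only a limit of this assay, > 30000 nM. Compound 3 `CN(c1cccc2c1CN(c1nc(Nc3cc(Cl)cc(C(F)(F)F)c3)ncc1C(F)(F)F)C2)S(C)(=O)=O` gives 5500 nM, the lowest of the two numbers shown: a 5.1-fold lower number from compound 1 to compound 3 (0.71 log units; beyond the scatter) and an at least 5.4-fold lower number from compound 2 to compound 3 (0.73 log units; beyond the scatter), whereas an at least 1.0-fold higher number from compound 1 to compound 2 (0.02 log units; that floor lies within the scatter). Compound 4 `Cc1cc(C)cc(Nc2ncc(C(F)(F)F)c(N3Cc4cccc(N(C)S(C)(=O)=O)c4C3)n2)c1` is not yet measured and differs from compound 3 by 3,5-dimethylphenyl in place of 3-chloro-5-(trifluoromethyl)phenyl on a nitrogen on an aromatic ring. Every measured step altered this same aryl group, and both steps arriving at 3-chloro-5-(trifluoromethyl)phenyl lay beyond the scatter, so giving up that group for 3,5-dimethylphenyl is expected to cost potency, a 2.9-fold higher number from compound 3 to compound 4 (0.46 log units; beyond the scatter). Compound 4 is estimated at 16000 nM, within 5000 nM to 40000 nM.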

Compound 4, concentration for 50% growth inhibition: > 30000 nM
Compound 4: a limit, no number; the forecaster's own chance of this, stated with the estimate: 25%; at least 1.8-fold (0.27 log units) between middle value and limit.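

In this assay compound 4 sits at a limit, > 30000 nM, and not at a number. The 3,5-dimethylphenyl group in place of the 3-chloro-5-(trifluoromethyl)phenyl group gives an at least 5.4-fold higher number from compound 3 to compound 4 (0.73 log units; beyond the scatter), so among these compounds the placement alone does not bring the activity of compound 3; the groups placed there count too. The comparison with the 4-chloro-2-methylphenyl group yields only an at least 1.0-fold higher number from compound 1 to compound 4 (0.02 log units; that floor lies within the scatter), and the step from compound 2 to compound 4 cannot be read because both sit at the same limit: the limit of > 30000 nM in this assay, at which 2 of the 4 values shown sit.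

Still open, on these data alone, is whether the chlorine or the trifluoromethyl counts for more, which a 3-chloro-5-methylphenyl group on this nitrogen would help to separate.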